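Working notes: from compound 2 to compound 3

The compounds below may be only part of what the source reports. "The series", "measured", "known", "first", "only" and "open" are said of these compounds alone.

In an ADME assay on microsomes from liver (Homo sapiens) for metabolic stability, read by LC-MS, tested at 1 uM (a higher number here means faster removal of the compound, a lower number slower removal), compound 1 (`c1cc([C@H]2CC[C@]3(CC2)OOC2(O3)C3CC4CC(C3)CC2C4)ccc1OCCCNC1CCOCC1`) gives 10 mL.min-1.g-1. Compound 2 (`c1cc([C@H]2CC[C@]3(CC2)OOC2(O3)C3CC4CC(C3)CC2C4)ccc1OCCOC1CCNCC1`) gives < 7 mL.min-1.g-1, which is a limit of the assay and not a number. That puts compound 2 at the limit of < 7 mL.min-1.g-1 in this assay, at which 1 of the 2 values shown sits.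

Compound 3 (`c1cc([C@H]2CC[C@]3(CC2)OOC2(O3)C3CC4CC(C3)CC2C4)ccc1OC1CCNCC1`) has not yet been measured. Its difference from compound 2 is piperidin-4-yl in place of 2-((piperidin-4-yl)oxy)ethyl on an oxygen on an aromatic ring, in words piperidin-4-yl in place of 2-((piperidin-4-yl)oxy)ethyl on an oxygen on an aromatic ring.

Among the compounds with values here, the only measured step that bears on this is an at least 1.4-fold lower number from compound 1 to compound 2 (0.15 log units; that floor lies within the scatter). That step is a different exchange, so it is a weak guide and gives no direction for the present change. Within the data shown here, no measured pair shows the present exchange itself. No change beyond the scatter is therefore expected in this assay.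

The expected step is a step that the limit leaves unreadable from compound 2 to compound 3. Compound 3 is estimated at 6 mL.min-1.g-1, with an expected range from 3 mL.min-1.g-1 to 12 mL.min-1.g-1. It is also expected that the result may be reported only as a limit.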

Compound 3, intrinsic clearance in microsomes: 15 mL.min-1.g-1
Beside the measured number, compound 3's estimate is 2.5-fold (0.40 log units) below it, outside the stated range (above it).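

In this assay, piperidin-4-yl in place of 2-((piperidin-4-yl)oxy)ethyl on an oxygen on an aromatic ring gives an at least 2.1-fold higher number from compound 2 to compound 3 (0.33 log units; beyond the scatter), so this position now has a step beyond the scatter, and it points towards faster removal. Compound 2 is reported as a limit and not a number, so this step gives only a floor and its true size stays unknown: the limit of < 7 mL.min-1.g-1 in this assay, at which 1 of the 3 values shown sits.

The other new comparison, piperidin-4-yl in place of 3-((oxan-4-yl)amino)propyl on the same oxygen, gives a 1.5-fold higher number from compound 1 to compound 3 (0.18 log units; within the scatter), so this assay does not separate these two groups, even though they differ in chain and in ring.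

The compounds shown do not tell whether the step follows the loss of the chain as a whole or the loss of its ether oxygen alone, and they give no reason for it. A group such as piperidin-4-ylmethyl on that oxygen, or a plain all-carbon chain ending in piperidin-4-yl, would bear on that question, and a measured number for a close relative of compound 2 would help fix the size of the step.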